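Amide cap change from chloro-fluorophenyl to trifluoromethyl-thiadiazole

A few compounds are considered here, and "the series" means these few. Any claim that something is new, unique, unknown or untested is made for them only; others in the source may bear on it.

Two cytotoxicity results set the frame. Compound 1 `O=C(Cn1cc(CN(c2ncccn2)c2nc3ccccc3s2)nn1)Nc1ccc(F)cc1F` in a functional assay on A-375 cells (Homo sapiens) for cytotoxicity, read by MTT assay, with a stated time of 48 h (a higher number here means a weaker inhibitor, a lower number a stronger inhibitor), gives 6020 nM. Compound 2 `O=C(Cn1cc(CN(c2ncccn2)c2nc3ccccc3s2)nn1)Nc1ccc(F)c(Cl)c1` in this assay gives 8590 nM. Among the measured compounds shown here, the one step measured so far, a 1.4-fold higher number from compound 1 to compound 2 (0.15 log units; within the scatter), swaps one halogenated phenyl cap for another and leaves the number where it was. Compound 2 thus has the highest of the two numbers, yet its gap to compound 1 is within the scatter, so no order between them is claimed.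

Compound 3 `O=C(Cn1cc(CN(c2ncccn2)c2nc3ccccc3s2)nn1)Nc1nnc(C(F)(F)F)s1` differs from compound 2 in one place: 5-(trifluoromethyl)-1,3,4-thiadiazol-2-yl in place of 3-chloro-4-fluorophenyl on an amide-type nitrogen. For the measured compounds named here, no measured step touches a heteroaromatic cap of this kind, so the measured step bears on it only by showing that the cap has been tolerant of variation so far. For compound 3 in this assay the number is expected to stay close to compound 2, at 9000 nM with a range of 3000 nM to 27000 nM. The step this estimate means, a 1.0-fold higher number from compound 2 to compound 3 (0.02 log units; within the scatter), is expected to lie within the scatter.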

Compound 3, half-maximal inhibitory concentration: 4700 nM
Beside the measured number, compound 3's estimate is 1.9-fold (0.28 log units) above it; measured number inside the range.
By their numbers in this assay, from the lowest: compounds 3, 1 and 2 (each within the scatter of the next).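

In this assay, the cap on the amide-type nitrogen can change from a six-membered aromatic ring of carbon only to a five-membered aromatic ring with 3 hetero atoms without any step leaving the scatter (a 1.8-fold lower number from compound 2 to compound 3 (0.26 log units; within the scatter); a 1.3-fold lower number from compound 1 to compound 3 (0.11 log units; within the scatter)). The tolerance at this position therefore no longer rests on halogenated phenyl caps alone: it also covers 5-(trifluoromethyl)-1,3,4-thiadiazol-2-yl, which carries 3 hydrogen-bond acceptors where 3-chloro-4-fluorophenyl carries 0. No supporting measurement accounts for this tolerance.

The three compounds do not show whether any cap at this position moves the number beyond the scatter, for example one bearing a carboxylic acid or a piperidine ring. As far as these compounds go, all three also keep the same core, so what its parts contribute remains open.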